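The source may report more compounds than this note shows. Statements on the series, on what has been measured and on what is new or still open speak of the compounds shown alone.

Three compounds sharing one core have been characterised in an assay on H9c2 cells for inhibition of tumor necrosis factor receptor superfamily member 6 (Rattus norvegicus), with stated times of 30 min and 6 h; on this read-out higher numbers stand for an effect only at larger amounts of compound and lower numbers for an effect already at smaller amounts. Compound 1 `COC(=O)c1sccc1NC(=O)CCSc1ccccc1` gives 501 nM in this assay. Compound 2 `COC(=O)c1sccc1NC(=O)CSc1ccc(Br)cc1` gives 427 nM in this assay, and compound 3 `COC(=O)c1sccc1NC(=O)CCSc1ccc(Br)cc1` gives 1290 nM in this assay. Compound 2 and compound 1 lie within the scatter of each other, while compound 3 stands apart from both with the highest of the three numbers.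

One pairing among the measured compounds differs in a single place: compound 3 and compound 1, with hydrogen in place of bromo on an aromatic carbon. This change gave a 2.6-fold lower number from compound 3 to compound 1 (0.41 log units; beyond the scatter).

Compound 4 `COC(=O)c1sccc1NC(=O)CSc1ccccc1` has not yet been measured in this assay. It differs from compound 2 by hydrogen in place of bromo on an aromatic carbon, the same kind of change as from compound 3 to compound 1. The difference between the core of compound 2 and the core of compound 3 is not broken down here, so it is not known whether the step seen in one core carries over to the other. For the measured compounds named here, the only guide is the single measured pairing, in which removing the bromo group lowered the number beyond the scatter.

Resting on that one step, compound 4 is expected to sit at a 1.9-fold lower number from compound 2 to compound 4 (0.29 log units; within the scatter) relative to compound 2. Compound 4 is estimated at 220 nM in this assay, with a plausible range from 110 nM to 450 nM.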

Compound 4, half-maximal effective concentration: 794 nM
Beside the measured number, compound 4's estimate is 3.6-fold (0.56 log units) below it; the measured number lies above the stated range.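

In this assay, for the compounds shown here, hydrogen in place of bromo on the core of compound 2 gave a 1.9-fold higher number from compound 2 to compound 4 (0.27 log units; within the scatter), so on this core the change produced no step that can be told from the scatter. Set beside the earlier case, the same change did not carry over from one core to the other: the same change on two cores in this assay, a 2.6-fold lower number (0.41 log units; beyond the scatter) from compound 3 to compound 1 and a 1.9-fold higher number (0.27 log units; within the scatter) from compound 2 to compound 4, 4.8-fold (0.68 log units) apart, beyond the scatter of two such steps. Within these four compounds, the step seen on one core was therefore no guide to the step on the other, but this does not show why the two cores respond differently, and with only one pairing on each core it gives no rule for the 4-bromophenyl to phenyl change on any further core.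

The compounds shown leave open whether other groups at that same place on the six-membered aromatic ring, such as chloro, methoxy or an amine, would follow either of the two steps, as only bromo and hydrogen appear there. Going by these compounds alone, they also leave open how the number would respond to a carboxylic acid in place of the methyl ester, or to a chain longer than the one in compound 1.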